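The source may hold more compounds than are shown below. What is called first, only, known or untested is meant among the compounds shown, and "the series" means these compounds.

In a physicochemical assay for solubility (on this read-out lower numbers stand for lower solubility and higher numbers for higher solubility), compound 1 (`CN(C)CC(=O)N1CCC(NS(=O)(=O)c2cc(S(=O)(=O)c3ccccc3)ccc2C(F)(F)F)CC1`) gives 100000 nM, compound 2 (`O=C([C@@H]1CCCN1C(=O)N1CCOCC1)N1CCC(NS(=O)(=O)c2cc(S(=O)(=O)c3ccccc3)ccc2C(F)(F)F)CC1`) gives 50000 nM and compound 3 (`CN1CCC[C@H]1C(=O)N1CCC(NS(=O)(=O)c2cc(S(=O)(=O)c3ccccc3)ccc2C(F)(F)F)CC1`) gives 100000 nM. Compound 3 thus stands level with compound 1 and within the scatter of compound 2. Compound 4 (`CC(C)(C)CCN1CCC[C@H]1C(=O)N1CCC(NS(=O)(=O)c2cc(S(=O)(=O)c3ccccc3)ccc2C(F)(F)F)CC1`) differs from compound 3 by one change: neopentyl in place of hydrogen on a saturated chain carbon bound to an amine nitrogen in a ring. For the measured compounds named here, two measured steps bear on it, no change at the digits printed from compound 1 to compound 3 (within the scatter) and a 2.0-fold higher number from compound 2 to compound 3 (0.30 log units; within the scatter), both within the scatter. Neither introduces neopentyl, so they offer only a weak guide. A moderately lower number is nevertheless expected in this assay, an estimated 3.3-fold lower number from compound 3 to compound 4 (0.52 log units; beyond the scatter). Compound 4 is estimated at 30000 nM, with an expected range of 6000 nM to 100000 nM.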

Compound 4, solubility: 12500 nM
Compound 4: the middle estimate sits 2.4-fold (0.38 log units) above what was measured; measured number inside the range.
By their numbers in this assay, from the lowest: compound 4; then compounds 2, 1 and 3 (each within the scatter of the next).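

Adding neopentyl on a saturated chain carbon bound to an amine nitrogen in a ring gives, in this assay, an 8.0-fold lower number from compound 3 to compound 4 (0.90 log units; beyond the scatter) in this set of compounds. For the compounds shown here, compound 4 also stands apart from the other two compounds, with a 4.0-fold lower number from compound 2 to compound 4 (0.60 log units; beyond the scatter) and an 8.0-fold lower number from compound 1 to compound 4 (0.90 log units; beyond the scatter) on the same read-out, whereas the steps among the earlier compounds stayed within the scatter. No evidence is available to explain this difference. As far as these compounds go, it remains open whether a shorter chain such as ethyl would give a number nearer that of compound 3. The same question applies to a 3,3-dimethylbutyl replacement carrying a terminal amine or carboxylic acid.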